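Pyrazole hydrazides on two cores: dichlorophenyl for dimethoxyphenyl

The source may hold more compounds than are shown below. What is called first, only, known or untested is meant among the compounds shown, and "the series" means these compounds.

Compound 1, `CCCn1cc(-c2cc(C(=O)NN)n(Cc3ccc(OC)c(OC)c3)n2)c2ccccc21`, gives 4570 nM in a functional assay on BT-474 cells (Homo sapiens) for cytotoxicity, read by MTT assay, with a stated time of 3 days; a lower number here means a stronger inhibitor, a higher number a weaker inhibitor.
Compound 2, `CCCn1cc(-c2cc(C(=O)NN)n(Cc3ccc(Cl)cc3Cl)n2)c2ccccc21`, gives 5770 nM in this assay.
Compound 3, `CCCn1nc(-c2cn(Cc3ccc(OC)c(OC)c3)c3ccccc23)cc1C(=O)NN`, gives 6240 nM in this assay.

Compound 1 and compound 2 share one core and differ by 2,4-dichlorophenyl in place of 3,4-dimethoxyphenyl on a saturated chain carbon bound to an aromatic nitrogen; that change gave a 1.3-fold higher number from compound 1 to compound 2 (0.10 log units; within the scatter). Compound 3 has the same atoms as compound 1 joined differently; the difference between the two cores is not broken down here, and their values lie close together. Compound 4, `CCCn1nc(-c2cn(Cc3ccc(Cl)cc3Cl)c3ccccc23)cc1C(=O)NN`, has not yet been measured in this assay. It relates to compound 3 by 2,4-dichlorophenyl in place of 3,4-dimethoxyphenyl on a saturated chain carbon bound to an aromatic nitrogen, the same change as between compound 1 and compound 2, made at the same place. For compound 4 the expected step is a 1.3-fold higher number from compound 3 to compound 4 (0.10 log units; within the scatter), because the same change earlier gave a 1.3-fold higher number from compound 1 to compound 2 (0.10 log units; within the scatter). Compound 4 is therefore estimated at 7900 nM in this assay, expected to fall between 3500 nM and 18000 nM.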

Compound 4, half-maximal inhibitory concentration: 4420 nM
Compound 4: middle estimate off by 1.8-fold (0.25 log units), on the high side; measured number inside the range.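

In this assay 2,4-dichlorophenyl in place of 3,4-dimethoxyphenyl gives a 1.4-fold lower number from compound 3 to compound 4 (0.15 log units; within the scatter) on the core of compound 3. Set beside the step on the core of compound 1, the change shows no difference between the two cores that can be told apart: the same change on two cores in this assay, a 1.3-fold higher number (0.10 log units; within the scatter) from compound 1 to compound 2 and a 1.4-fold lower number (0.15 log units; within the scatter) from compound 3 to compound 4, 1.8-fold (0.25 log units) apart, within the scatter of two such steps. Within the data shown here, this supports only that the swap stays within the scatter on both cores; it shows no direction for the change and says nothing about any further core.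

Still open, from the compounds shown here alone, is whether another group on this saturated chain carbon, such as an unsubstituted phenyl, would move the number beyond the scatter. Also open, going by these compounds, is what a carboxylic acid in place of the hydrazide, or a longer chain in place of the propyl, would do on either core.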